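A few compounds are considered here, and "the series" means these few. Any claim that something is new, unique, unknown or untested is made for them only; others in the source may bear on it.

Measured compounds:
- compound 1 `O=C(Nc1ccccc1)c1ccc(/N=N\c2c[nH]c3ccccc23)cc1`: "not active" (no number reported)
- compound 2 `Cc1cccc(NC(=O)c2ccc(/N=N\c3c[nH]c4ccccc34)cc2)c1C`: 51600 nM
- compound 3 `O=C(Nc1cccc(Cl)c1)c1ccc(/N=N\c2c[nH]c3ccccc23)cc1`: 267000 nM

Compound 1 carries an unsubstituted phenyl on the amide nitrogen; in a functional assay on P388 cells (Mus musculus) for inhibition, read by MTT assay, with a stated time of 72 h (a lower number here means a stronger inhibitor, a higher number a weaker inhibitor), compound 1 is recorded as "not active" (no number reported), with no number given. Compound 2, which carries 2,3-dimethylphenyl there, gives 51600 nM in this assay. Within the data shown here, compound 3, with 3-chlorophenyl, gives 267000 nM in this assay and so stands highest of the two numbers available; the one step leading to it, a 5.2-fold higher number from compound 2 to compound 3 (0.71 log units; beyond the scatter), is beyond the scatter.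

Compound 4 `Cc1ccccc1NC(=O)c1ccc(/N=N\c2c[nH]c3ccccc23)cc1` has not been measured in this assay. It differs from compound 3 by 2-methylphenyl in place of 3-chlorophenyl on an amide-type nitrogen. Among the measured compounds shown here, the only measured step that bears on this is a 5.2-fold higher number from compound 2 to compound 3 (0.71 log units; beyond the scatter), where a methylated phenyl gave the lower number and the chlorophenyl the higher. A single methyl on the phenyl sits between the unsubstituted phenyl of compound 1, which returned no number, and the dimethylphenyl of compound 2. A moderate move downward from compound 3 is therefore expected, a 2.2-fold lower number from compound 3 to compound 4 (0.35 log units; beyond the scatter), though with the unsubstituted compound 1 returning no number the chance that compound 4 also returns none is real. Compound 4 is estimated at 120000 nM, within 40000 nM to 400000 nM.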

Compound 4, half-maximal inhibitory concentration: "not active" (no number reported)
No number was reported for compound 4; the estimate stays without a comparison.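

Compound 4 is recorded as "not active" (no number reported) and gives no number to set against compound 3, so no new step can be read. Nothing shown here bears on this result. The compounds shown leave open how far compound 1 and compound 4 lie from compound 2 and compound 3 on a numerical scale.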